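The source may report more compounds than this note shows. Statements on the series, on what has been measured and on what is new or still open speak of the compounds shown alone.

Measured compounds in an ADME assay on MT4 cells (Homo sapiens) for cytotoxicity; a higher number here means that more compound is tolerated, a lower number that less compound is tolerated:

- compound 1, `O=C(CSc1snnc1-c1ccccc1)Nc1ccccc1F`: in this assay compound 1 gives > 361000 nM
- compound 2, `CCOC(=O)c1ccc(NC(=O)CSc2snnc2-c2ccccc2)c(Br)c1`: in this assay compound 2 gives >= 232000 nM
- compound 3, `Cc1ccc(NC(=O)CSc2snnc2-c2ccc(Cl)cc2Cl)c(Br)c1`: in this assay compound 3 gives > 255000 nM

Each of these three readings is a limit of the assay and not a number. Compound 1 sits at the limit of > 361000 nM in this assay, at which 1 of the 3 values shown sits, so for it only a limit is known. Compound 2 rests at the limit of >= 232000 nM in this assay, at which 1 of the 3 values shown sits. Compound 3 rests at the limit of > 255000 nM in this assay, at which 1 of the 3 values shown sits. For the measured compounds named here, nothing in these three values sets any of the compounds apart from the others, and no step between measured compounds can be read off.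

Compound 4, `O=C(CSc1snnc1-c1ccccc1)Nc1ccccc1Cl`, is the next compound to be measured in this assay. It differs from compound 1 in one place: chloro in place of fluoro on an aromatic carbon. Going by the values given here, since compound 1 itself reaches only a limit in this assay, and the two other measured compounds do the same, there is no measured step from which a direction could be taken. The change from compound 1 to compound 4 is expected to give no step beyond the usual scatter, that is an at least 1.0-fold lower number from compound 1 to compound 4 (0.01 log units; that floor lies within the scatter). Compound 4 is therefore estimated at 350000 nM, with a likely range from 150000 nM to 800000 nM, and most probably the assay will again report a limit rather than a number.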

Compound 4, half-maximal cytotoxic concentration: > 345000 nM
Compound 4: a limit, no number (the forecaster's own chance of this, stated with the estimate: 85%); the middle value is on the limit's open side.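

In this assay compound 4 gives > 345000 nM, which is a limit and not a number. Compound 1 likewise reaches only a limit, so no step can be read between compound 1 and compound 4. The compounds shown leave open at what concentration any of them becomes cytotoxic, and whether 2-fluorophenyl to 2-chlorophenyl changes that concentration at all.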